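Lengthening an Alkoxy Chain on a Shared Core

A few compounds are considered here, and "the series" means these few. Any claim that something is new, unique, unknown or untested is made for them only; others in the source may bear on it.

Compound 2 `C=CCc1cc(C(C)=O)c(O)cc1OCCCC` and compound 1 `C=CCc1cc(C(C)=O)c(O)cc1OCCCCCCCCCCC#N` have the same core and differ only in what hangs from the end of the chain that leaves the ring oxygen. In an assay on isolated protein for binding affinity to leukotriene B4 receptor 1 (Homo sapiens), tested at 1 uM (a higher number here means more inhibition at the concentration tested (going by the name of the read-out), a lower number less inhibition), compound 2 gives 8%, the lower of the two numbers shown, while compound 1 gives 14%. Within the data shown here, the one measured step, a number 6 percentage points lower from compound 1 to compound 2 (within the scatter), is within the scatter, so these two numbers cannot truly be told apart.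

Compound 3 `C=CCc1cc(C(C)=O)c(O)cc1OCCCCCCC` has not been measured. It differs from compound 2 by propyl in place of hydrogen on a saturated chain carbon, four bonds along the chain from an oxygen on an aromatic ring. Among the measured compounds shown here, this is the same chain carbon where compound 1 carries its 6-cyanohexyl group, so the step between compound 1 and compound 2 is the only measurement that bears on it: a longer chain at this carbon gave a number higher by a margin that stayed within the scatter. A propyl group is shorter than a 6-cyanohexyl group and brings no nitrile, so no step beyond the scatter is expected in this assay; the estimated change is a number 4 percentage points higher from compound 2 to compound 3 (within the scatter). Compound 3 is therefore expected to give 12%, with a range from 3% to 25%.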

Compound 3, a percentage reported as inhibition, at one concentration (the size of the read-out at that concentration, not a potency): 8%
The estimate for compound 3 lay 4 percentage points above the measured number; low and high end bracket the measured number.
By their numbers in this assay, from the lowest: compounds 2, 3 and 1 (each within the scatter of the next).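

Placing propyl on the saturated chain carbon, four bonds along the chain from an oxygen on an aromatic ring, gives no change at the digits printed from compound 2 to compound 3 (within the scatter) in this assay for this plain hydrocarbon extension, which adds a direct reading for a chain without a nitrile to what the earlier pair showed. The second new comparison isolates the outer part of the chain: removing 3-cyanopropyl, seven bonds along the chain from that oxygen, gives a number 6 percentage points lower from compound 1 to compound 3 (within the scatter) and so also leaves the numbers indistinguishable. Across hydrogen, propyl and 6-cyanohexyl at the four-bond carbon, no step rises above the scatter, and no independent measurement is available to account for this.

These three compounds leave open whether a chain ending in an amine, a carboxylic acid or a phenyl ring would give a number clearly separate from those seen so far. A single-concentration read-out also leaves open how the potencies of these compounds compare, and a full concentration series would be needed to address that.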